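From a dimethylamino chain to an aminocyclohexyl group

The source may report more compounds than this note shows. Statements on the series, on what has been measured and on what is new or still open speak of the compounds shown alone.

compound 1 `CSc1nc(NCc2ccc(-c3ccccn3)cc2)c2[nH]nc(C(C)C)c2n1` gives 2800 nM
compound 2 `CC(C)c1n[nH]c2c(NCc3ccc(-c4ccccn4)cc3)nc(NCCN)nc12` gives 227 nM
compound 3 `CC(C)c1n[nH]c2c(NCc3ccc(-c4ccccn4)cc3)nc(NCCN(C)C)nc12` gives 390 nM

In a functional assay on HCT-116 cells (Homo sapiens) for cytotoxicity, read by fluorescence, with a stated time of 72 h (a higher number here means a weaker inhibitor, a lower number a stronger inhibitor), compound 3 stands in the lower pair of numbers. The closest comparison is a 1.7-fold higher number from compound 2 to compound 3 (0.24 log units; within the scatter) and the furthest is a 7.2-fold lower number from compound 1 to compound 3 (0.86 log units; beyond the scatter) on the same scale.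

Compound 4 `CC(C)c1n[nH]c2c(NCc3ccc(-c4ccccn4)cc3)nc(N[C@H]3CC[C@H](N)CC3)nc12` differs in one place, where 4-aminocyclohexyl stands in place of 2-(dimethylamino)ethyl on a nitrogen on an aromatic ring 4-aminocyclohexyl in place of 2-(dimethylamino)ethyl on a nitrogen on an aromatic ring and brings in a six-membered non-aromatic ring of carbon only.

Putting (2-aminoethyl)amino in place of methylsulfanyl gave a 12-fold lower number from compound 1 to compound 2 (1.09 log units; beyond the scatter) as a large drop, so both measured amino-bearing chains sit well under the methylsulfanyl compound. Swapping the chain end between amino and dimethylamino stayed within the scatter. Going by the values given here, no measured compound carries a ring on this nitrogen, so the size of the next step is uncertain.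

A modest drop is expected, namely a 3.3-fold lower number from compound 3 to compound 4 (0.51 log units; beyond the scatter) in this assay as the estimated change. For compound 4 the estimated value is 120 nM with an expected range from 30 nM to 450 nM.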

Compound 4, half-maximal inhibitory concentration: 720 nM
Compound 4: middle estimate off by 6.0-fold (0.78 log units), on the low side; measured number outside the range, above it.
By their numbers in this assay, from the lowest: compounds 2, 3 and 4 (each within the scatter of the next, the first and the last beyond it); then compound 1.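

In this assay, a ring on this nitrogen does not set the result apart from the dimethylamino chain: 4-aminocyclohexyl in place of 2-(dimethylamino)ethyl gives a 1.8-fold higher number from compound 3 to compound 4 (0.27 log units; within the scatter) and so cannot be told from it. The ring does separate from the 2-aminoethyl chain, with a 3.2-fold higher number from compound 2 to compound 4 (0.50 log units; beyond the scatter) as a step beyond the scatter, yet the amino-bearing ring still improves on methylsulfanyl, with a 3.9-fold lower number from compound 1 to compound 4 (0.59 log units; beyond the scatter) on that comparison. No measurement available here explains these steps.

As far as these compounds go, whether a longer chain such as 3-aminopropyl, or a piperidine ring, would fall nearer compound 2 or compound 4 stays open. With one ring compound shown, it is also open how far the ring itself, the place of its amino group or the arrangement of its two stereocentres shapes the result.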